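Swapping the amide-bound aryl ring on a shared quinazoline-free core

A few compounds are considered here, and "the series" means these few. Any claim that something is new, unique, unknown or untested is made for them only; others in the source may bear on it.

Measured so far:
compound 1, `O=C(CSc1nc(Nc2ccccc2)c2ccccc2n1)Nc1ccccc1Br`: 14100 nM
compound 2, `CCc1ccc(NC(=O)CSc2nc(Nc3ccccc3)c3ccccc3n2)cc1`: 33900 nM

Both compounds share one core and differ only in the aryl ring on the amide-type nitrogen. In a functional assay on MDA-MB-231 cells (Homo sapiens) for inhibition, read by MTT assay, with a stated time of 72 h (a lower number here means a stronger inhibitor, a higher number a weaker inhibitor), compound 1 gives 14100 nM, and compound 2 gives 33900 nM. Compound 2 therefore holds the higher of the two numbers; the step of a 2.4-fold higher number from compound 1 to compound 2 (0.38 log units; beyond the scatter) shows how much weaker it is than compound 1.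

Compound 3, `O=C(CSc1nc(Nc2ccccc2)c2ccccc2n1)Nc1ccc(Cl)cc1Cl`, has not yet been measured. Its change from compound 2 is 2,4-dichlorophenyl in place of 4-ethylphenyl on an amide-type nitrogen. For the measured compounds named here, the only step that bears on it is a 2.4-fold higher number from compound 1 to compound 2 (0.38 log units; beyond the scatter), where leaving a bromine-bearing phenyl for the 4-ethylphenyl raised the number. Returning to a halogen-bearing ring, now with two chlorine atoms, is expected to move the number back down, by roughly a 2.3-fold lower number from compound 2 to compound 3 (0.35 log units; beyond the scatter). Compound 3 is thus expected to give about 15000 nM in this assay, with a range from 6000 nM to 40000 nM.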

Compound 3, half-maximal inhibitory concentration: 19400 nM
For compound 3 the middle estimate is 1.3-fold (0.11 log units) below the measured one, and the stated range covers the measured number.
By their numbers in this assay, from the lowest: compounds 1, 3 and 2 (each within the scatter of the next, the first and the last beyond it).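

In this assay, 2,4-dichlorophenyl on the amide-type nitrogen gives a 1.7-fold lower number from compound 2 to compound 3 (0.24 log units; within the scatter) and, set against the 2-bromophenyl ring, a 1.4-fold higher number from compound 1 to compound 3 (0.14 log units; within the scatter) so compound 3 cannot be told apart from either of the others, even though compound 1 and compound 2 can be told apart from each other. At this position, then, exchanging 2-bromophenyl for 2,4-dichlorophenyl makes no readable difference, and the same holds for exchanging 4-ethylphenyl for 2,4-dichlorophenyl. Nothing available here explains these results.

From the compounds shown here alone, it remains open whether a phenyl ring carrying an amine or a carboxylic acid on the amide-type nitrogen would move the number well beyond the scatter. Going by these compounds, it is also open whether a longer chain in place of the ring would do so.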